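Swapping dimethylphenyl for chlorophenyl at the ether oxygen

The source may report more compounds than this note shows. Statements on the series, on what has been measured and on what is new or still open speak of the compounds shown alone.

Of the compounds shown here, three that share one core have been measured in an assay on isolated protein for inhibition of Dihydrofolate reductase (Homo sapiens), read by spectrophotometry, using NADPH, with stated times of 5 s and 6 min, tested at 50 uM; a lower number here means a weaker effect, a higher number a stronger effect of the compound at the concentration tested. In this assay compound 1 `CC(C)(C)c1ccc(OCCCON2C(N)=NC(N)=NC23CCSCC3)cc1` gives 86.6%. Compound 2 `NC1=NC2(CCOCC2)N(OCCCOc2cccc(Cl)c2Cl)C(N)=N1` gives 89.8% in this assay, and compound 3 `Cc1cc(C)cc(OCCCON2C(N)=NC(N)=NC23CCOCC3)c1` gives 88.6% in this assay. Compound 3 holds the middle of the three numbers, but its gap to compound 2, the nearer of the two, and its gap to compound 1, the wider one, both lie within the scatter, so the three compounds cannot be told apart on these readings. Among the measured compounds shown here, only one step joins two of them through a change in a single place: a number 1.2 percentage points lower from compound 2 to compound 3 (within the scatter), with 3,5-dimethylphenyl in place of 2,3-dichlorophenyl on an oxygen on a saturated carbon.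

Compound 4 `NC1=NC2(CCOCC2)N(OCCCOc2cccc(Cl)c2)C(N)=N1` has not yet been measured. It differs from compound 3 by 3-chlorophenyl in place of 3,5-dimethylphenyl on an oxygen on a saturated carbon. The step from compound 2 to compound 3 is the one that bears on this change, since it too exchanges a chlorinated phenyl and the dimethylphenyl at the same place, only in the other direction, and it stayed within the scatter. The change to compound 4 is therefore expected to give a step of a number 0.6 percentage points lower from compound 3 to compound 4 (within the scatter), nothing beyond the scatter. Compound 4 is estimated to give 88% in this assay, with a range from 80% to 95%.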

Compound 4, a percentage reported as inhibition, at one concentration (the size of the read-out at that concentration, not a potency): 85.8%
The estimate for compound 4 lay 2.2 percentage points above the measured number, within the range that was stated.
By their numbers in this assay, from the lowest: compounds 4, 1, 3 and 2 (each within the scatter of the next).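

With 3-chlorophenyl in place of 3,5-dimethylphenyl on the oxygen, this assay shows a number 2.8 percentage points lower from compound 3 to compound 4 (within the scatter), so a ring carrying a single chloro group cannot be told apart from the dimethylphenyl ring on this reading. Among the compounds shown here, the new compound also gives the first step in which only the number of chloro groups on the ring changes: with hydrogen in place of chloro on an aromatic carbon, the reading is a number 4 percentage points lower from compound 2 to compound 4 (within the scatter), so the dichlorophenyl and the 3-chlorophenyl compounds cannot be told apart either. Together with the earlier step, this means that all three ring groups compared on this core give readings that stay within the scatter of one another, and nothing measured here offers an explanation for the readings.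

All the rings shown carry chloro or alkyl groups, so it remains open how a plain phenyl ring, or a phenyl ring bearing an amine or a carboxylic acid, would read at this position. From the compounds shown here alone, because each reading comes from one concentration, it also remains open whether compounds that read alike here would differ in potency.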